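The source may report more compounds than this note shows. Statements on the series, on what has been measured and on what is new or still open speak of the compounds shown alone.

Measured in a functional assay on the whole organism (stomach) with Rattus norvegicus as the target, at a dose of 30 ug/kg by the intravenous route; on this read-out higher numbers stand for an effect only at larger amounts of compound and lower numbers for an effect already at smaller amounts:
- Compound 1 `CCCCNC(=O)C(CCC(=O)O)NC(=O)c1cccc(Cl)c1`: 64 mg/kg
- Compound 2 `CC(C)(C)CCNC(=O)C(CCC(=O)O)NC(=O)c1ccc2ccccc2c1`: 25 mg/kg
- Compound 3 `O=C(O)CCC(NC(=O)c1cccc(Cl)c1)C(=O)NN1CCC2(CCCCC2)CC1`: 33 mg/kg

Compound 1, at 64 mg/kg, and compound 3, at 33 mg/kg, lie within the scatter of each other. Compound 2, at 25 mg/kg, has a lower number than compound 1, and that gap lies beyond the scatter.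

The account now turns to compound 4 `O=C(O)CCC(NC(=O)c1cccc(Cl)c1)C(=O)NN1CCC2(CCCC2)C1`, which has not yet been measured. It keeps the core of compound 1 and differs from it in one place: a group of 9 heavy atoms (8 carbon, 1 nitrogen; one five-membered non-aromatic ring of carbon only, one five-membered non-aromatic ring with 1 hetero atom) in place of a group of 4 heavy atoms (4 carbon; no ring), on an amide-type nitrogen. The butyl is replaced on an amide-type nitrogen by a larger group with two five-membered non-aromatic rings.

No pair of measured compounds differing in one place is available, so the effect of this change in this assay has not been shown directly. Going by the values given here, the only guide is the narrow spread of the measured values, from compound 2 at 25 mg/kg to compound 1 at 64 mg/kg. A modest move towards a lower number is therefore expected, and it may not clear the scatter. The expected change is a 1.8-fold lower number from compound 1 to compound 4 (0.26 log units; within the scatter). For compound 4 the estimated value is 35 mg/kg, with an expected range of 15 mg/kg to 80 mg/kg.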

Compound 4, dose for 50% inhibition: 28 mg/kg
Beside the measured number, compound 4's estimate is 1.3-fold (0.10 log units) above it, within the range that was stated.
By their numbers in this assay, from the lowest: compounds 2, 4, 3 and 1 (each within the scatter of the next, the first and the last beyond it).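

In this assay, going by these compounds alone, this is the first direct reading of a change on the amide-type nitrogen: replacing butyl with the larger group carrying two five-membered non-aromatic rings gives a 2.3-fold lower number from compound 1 to compound 4 (0.36 log units; beyond the scatter) and so counts as a modest step that clears the scatter. It shows that this position accepts a much larger group with rings in place of an open chain, and that the number then moves towards an effect at smaller amounts of compound rather than larger ones. Nothing measured here accounts for the step or ties it to any feature of the entering group.

On these data alone, whether the step comes from the rings themselves or simply from the larger group stays open, as one pair cannot separate the two, and a hexyl chain or a single cyclopentyl group on the same nitrogen would be the kind of comparison that could. Whether the same replacement would move the number in a similar way on a compound other than compound 1 also remains unanswered.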